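This account rests on a few compounds, and the source may have more. Where it says the series, first, only, none or still open, it means among the compounds named here.

Measured compounds in a functional assay on MCF7 cells (Homo sapiens) for antiproliferative activity, read by MTT assay, with a stated time of 48 h; a higher number here means a weaker inhibitor, a lower number a stronger inhibitor:
compound 1, `N#CC1=C(N)Oc2c(c3nc4ccccc4nc3c3ccccc23)C12C(=O)N(Cc1cnnn1-c1ccccc1Br)c1ccccc12`, > 50000 nM (a limit of the assay)
compound 2, `N#CC1=C(N)Oc2c(c3nc4ccccc4nc3c3ccccc23)C12C(=O)N(Cc1cnnn1-c1ccc([N+](=O)[O-])cc1)c1ccccc12`, > 50000 nM (a limit of the assay)
compound 3, `N#CC1=C(N)Oc2c(c3nc4ccccc4nc3c3ccccc23)C12C(=O)N(Cc1cnnn1-c1cccc(S(N)(=O)=O)c1)c1ccccc12`, 42500 nM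

For the measured compounds named here, compound 3 stands alone as the only number in this assay. For compound 1 the value > 50000 nM is a limit of the assay, not a number. For compound 2 likewise the value > 50000 nM is a limit. Note (the limit of > 50000 nM in this assay, at which 2 of the 3 values shown sit), which is where two of the three results sit, and the number for compound 3 is close to it.

Compound 4, `Cc1ccc(-n2nncc2CN2C(=O)C3(C(C#N)=C(N)Oc4c3c3nc5ccccc5nc3c3ccccc43)c3ccccc32)cc1Cl`, differs from compound 3 in one place: 3-chloro-4-methylphenyl in place of 3-sulfamoylphenyl on an aromatic nitrogen. Going by the values given here, the steps that bear on this change are the other exchanges at the same aromatic nitrogen. The step of an at least 1.1-fold lower number from compound 1 to compound 3 (0.07 log units; that floor lies within the scatter) and the step of an at least 1.1-fold lower number from compound 2 to compound 3 (0.07 log units; that floor lies within the scatter) are both only floors whose size lies within the scatter, and the step that the two limits leave unreadable from compound 1 to compound 2 cannot be read at all. Every exchange of the aryl group on this nitrogen so far has left the readout at or near the limit, so no step beyond the scatter is expected in this assay from compound 3 to compound 4, and a limit rather than a number is a real possibility. Compound 4 is therefore estimated at 45000 nM, within 15000 nM to 150000 nM. The step this estimate implies, a 1.1-fold higher number from compound 3 to compound 4 (0.02 log units; within the scatter), is expected to stay within the scatter.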

Compound 4, half-maximal inhibitory concentration: > 50000 nM
Compound 4 gave a limit, no number; the forecaster's own chance of this, stated with the estimate: 55%; middle value at least 1.1-fold (0.04 log units) from the limit.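

In this assay compound 4 gives > 50000 nM, a limit of the assay and not a number. The exchange at the aromatic nitrogen gives an at least 1.1-fold higher number from compound 3 to compound 4 (0.07 log units; that floor lies within the scatter), so taking out 3-sulfamoylphenyl, with its hydrogen-bond donor and acceptors, and putting in 3-chloro-4-methylphenyl, which has neither, yields only a floor within the scatter and no readable loss. The steps to compound 4 from compound 1 and from compound 2 cannot be read, and the new point is that an aryl group carrying only carbon and chlorine on this nitrogen ends at the same ceiling as the bromo and nitro aryl groups, which leaves the series pressed against one boundary: the limit of > 50000 nM in this assay, at which 3 of the 4 values shown sit.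

Still open, as far as these compounds go, is whether any group on this nitrogen gives a number clearly clear of that limit, for instance a phenyl ring carrying a carboxylic acid or an amine, or a simple alkyl chain in place of the aryl ring. With the core the same in all the compounds shown, it also remains open whether a change away from this nitrogen would shift the readout at all.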